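The source may report more compounds than this note shows. Statements on the series, on what has been measured and on what is new or still open speak of the compounds shown alone.

Measured so far in a functional assay on B16 cells (Mus musculus) for antiproliferative activity, with a stated time of 72 h; a lower number here means a stronger inhibitor, a higher number a weaker inhibitor:
compound 1 `OCC#CCSc1cnc2ccccc2c1SCC#CCCl`, 43.4 ug/mL
compound 2 `CSc1cnc2ccccc2c1SCC#CCOC(=O)/C=C/c1ccccc1`, 9.4 ug/mL
compound 3 `C#CCSc1cnc2ccccc2c1SCC#CCOC(=O)/C=C/c1ccccc1`, 14.7 ug/mL

Compound 2 gives the lowest number of the three in this assay. The nearest is compound 3, and the step of a 1.6-fold higher number from compound 2 to compound 3 (0.19 log units; within the scatter) is within the scatter, so the two cannot be told apart; the gap to compound 1, which carries no ester at all and gives 43.4 ug/mL, is beyond the scatter.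

Compound 4 `CSc1cnc2ccccc2c1SCC#CCOC(=O)c1ccc(C(=O)O)cc1` is not yet measured. It differs from compound 2 in one place: 4-carboxyphenyl in place of 2-phenylethenyl on a carbonyl carbon.

For the measured compounds named here, no measured step touches this carbonyl carbon. Going by the values given here, the only step available, from compound 2 to compound 3, alters the group on the sulfur-bound chain carbon and is within the scatter, so it gives no direct guide to an exchange of the ester acid part. Among the compounds with values here, the measured compounds show only that compound 2 and compound 3, both carrying the 2-phenylethenyl ester, sit in the same range, while compound 1 without the ester is higher. For compound 4 the expected step of a 1.6-fold higher number from compound 2 to compound 4 (0.20 log units; within the scatter) is therefore small, with wide uncertainty in either direction. The estimate for compound 4 in this assay is 15 ug/mL, with a range from 6 ug/mL to 40 ug/mL.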

Compound 4, concentration for 50% inhibition: 18.1 ug/mL
The estimate for compound 4 lay 1.2-fold (0.08 log units) below the measured number; measured number inside the range.
By their numbers in this assay, from the lowest: compounds 2, 3 and 4 (each within the scatter of the next); then compound 1.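

In this assay, for the compounds shown here, the exchange on the carbonyl carbon gives a 1.9-fold higher number from compound 2 to compound 4 (0.28 log units; within the scatter), so compound 2 and compound 4 cannot be told apart, and this is the first reading of a change at this position. Going by these compounds alone, the 2-phenylethenyl group is therefore not the only group here compatible with a number in this range: 4-carboxyphenyl, with its two oxygens, one hydrogen-bond donor and one hydrogen-bond acceptor, gives a result within the scatter of compound 2 in this assay. No measurement on these compounds bears on why the two groups read alike.

Still open, on these data alone, is how far this tolerance extends, since one exchange cannot show whether the carboxylic acid itself matters: the methyl ester of that acid, an amine in its place, or an unsubstituted phenyl group would test this, and a saturated alkyl chain on the carbonyl carbon would test whether any aromatic ring is needed. As far as these compounds go, it is also open whether 4-carboxyphenyl reads the same when paired with the ethynyl-bearing sulfur chain of compound 3.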